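Bis(indolyl)methanes against ME18 cells: core swap, aryl swap

This account rests on a few compounds, and the source may have more. Where it says the series, first, only, none or still open, it means among the compounds named here.

Three compounds of the series carry measured values. Compound 1 `Cc1ccc(C(c2c[nH]c3ccc(I)cc23)c2c[nH]c3ccc(I)cc23)cc1` and compound 2 `Fc1cc(F)cc(C(c2c[nH]c3ccc(I)cc23)c2c[nH]c3ccc(I)cc23)c1` share one core; compound 3 `COc1ccc2[nH]cc(C(c3ccc(C)cc3)c3c[nH]c4ccc(OC)cc34)c2c1` stands on a second core, and the difference between the two cores is not broken down here. In a functional assay on ME18 cells (Homo sapiens) for cytotoxicity, read by MTT assay, with a stated time of 48 h (on this read-out higher numbers stand for weaker inhibition and lower numbers for stronger inhibition), compound 1 gives 21100000 nM, compound 2 gives 23800000 nM, and compound 3 gives 33000000 nM. All three numbers sit within the scatter of one another, so no order among them can be read from this set.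

On the first core the aryl exchange is already measured: 3,5-difluorophenyl in place of 4-methylphenyl on a saturated chain carbon bound to two aromatic carbons, with a 1.1-fold higher number from compound 1 to compound 2 (0.05 log units; within the scatter). Compound 4 `COc1ccc2[nH]cc(C(c3cc(F)cc(F)c3)c3c[nH]c4ccc(OC)cc34)c2c1` applies the same change to the core of compound 3: 3,5-difluorophenyl in place of 4-methylphenyl on a saturated chain carbon bound to two aromatic carbons. Both place lines read alike, so this is the same change on a different core.

Going by the values given here, for compound 4 the step is expected to be a 1.1-fold higher number from compound 3 to compound 4 (0.04 log units; within the scatter), close to the flat step seen from compound 1 to compound 2, since the only measured instance of this change moved nothing beyond the scatter. Compound 4 is therefore estimated at 36000000 nM in this assay, with a range of 18000000 nM to 75000000 nM.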

Compound 4, half-maximal inhibitory concentration: 28200000 nM
Beside the measured number, compound 4's estimate is 1.3-fold (0.11 log units) above it; the range from low to high includes it.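

In this assay, 3,5-difluorophenyl in place of 4-methylphenyl on the second core gives a 1.2-fold lower number from compound 3 to compound 4 (0.07 log units; within the scatter). Set beside the earlier instance, the two steps do not differ: the same change on two cores in this assay, a 1.1-fold higher number (0.05 log units; within the scatter) from compound 1 to compound 2 and a 1.2-fold lower number (0.07 log units; within the scatter) from compound 3 to compound 4, 1.3-fold (0.12 log units) apart, within the scatter of two such steps On these two cores the exchange therefore carries over as a step within the scatter, but this rests on one pair of aryl groups on each of two cores, and it does not show that the exchange would stay flat on any other core or that either aryl group is without effect in other settings.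

The compounds shown leave open whether any group on the saturated chain carbon bound to two aromatic carbons moves the number beyond the scatter, for instance a phenyl bearing an amine or a carboxylic acid, or a longer chain in place of the aryl group. Going by these compounds alone, they also leave the effect of the core itself unresolved, as no step between the two cores is available here.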